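Swapping nitrile for fluorine on a weak glucagon antagonist

The source may hold more compounds than are shown below. What is called first, only, known or untested is meant among the compounds shown, and "the series" means these compounds.

Compound 1 `CCCC(Oc1ccc(-n2cc(C(F)(F)F)c(C)n2)cc1)c1ccc(C(=O)NCCC(=O)O)cc1` gives 8300 nM in a functional assay on cells for antagonist activity at Glucagon receptor (Homo sapiens), read by cAMP accumulation, in the presence of a further agent that is not named here; a higher number here means a weaker inhibitor, a lower number a stronger inhibitor.
Compound 2 `CCCC(Oc1ccc(-n2cc(C#N)cn2)cc1)c1ccc(C(=O)NCCC(=O)O)cc1` gives > 50000 nM in this assay, which is a limit of the assay and not a number.

Compound 2 therefore sits at the top edge of what can be measured, as the limit of > 50000 nM in this assay, at which 1 of the 2 values shown sits, records. For the measured compounds named here, the one measured step, an at least 6.0-fold higher number from compound 1 to compound 2 (0.77 log units; beyond the scatter), exchanges a pyrazole bearing trifluoromethyl and methyl for one bearing cyano. Compound 3 `CCCC(Oc1ccc(-n2cc(F)cn2)cc1)c1ccc(C(=O)NCCC(=O)O)cc1` differs from compound 2 by fluoro in place of cyano on an aromatic carbon. Going by the values given here, no measured step covers this exchange, and the limit on compound 2 leaves the starting point open. Compound 3 is expected to give 45000 nM, within 12000 nM to 170000 nM, so the expected step of an at least 1.1-fold lower number from compound 2 to compound 3 (0.04 log units; that floor lies within the scatter) stays within the scatter.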

Compound 3, antagonist equilibrium constant: 10000 nM
Compound 3: middle estimate off by 4.5-fold (0.65 log units), on the high side; the whole stated range lies above it.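

On this aromatic carbon, fluoro in place of cyano gives a measurable value again, with an at least 5.0-fold lower number from compound 2 to compound 3 (0.69 log units; beyond the scatter). Compound 2 holds a limit of the assay and not a number, so that step is only a floor: the limit of > 50000 nM in this assay, at which 1 of the 3 values shown sits. The 4-fluoro-1H-pyrazol-1-yl and 3-methyl-4-(trifluoromethyl)-1H-pyrazol-1-yl groups cannot be told apart here, with a 1.2-fold higher number from compound 1 to compound 3 (0.08 log units; within the scatter).

Still open, as far as these compounds go, is how a chloro or methoxy group on this same carbon would read in this assay. Also open, from the compounds shown here alone, is whether the methyl group of compound 1 matters on its own.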